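Open-chain Branching in Place of a Ring

A few compounds are considered here, and "the series" means these few. Any claim that something is new, unique, unknown or untested is made for them only; others in the source may bear on it.

Measured compounds:
- Compound 1, `CC(C)OCCOc1cccc2ccc(N)nc12`: > 2000 nM in an assay on cells with melanin-concentrating hormone receptor 1 (Homo sapiens) as the target, read by radioligand binding; on this read-out lower numbers stand for stronger inhibition and higher numbers for weaker inhibition
- Compound 2, `CC1CCC(Oc2cccc3ccc(N)nc23)C1`: 823 nM

Compound 1 gives only a limit in this assay, (the limit of > 2000 nM in this assay, at which 1 of the 2 values shown sits), and not a number. For the measured compounds named here, compound 2 is therefore the only compound with a measured number, and the single other value recorded is a limit. Going by the values given here, the one step that can be measured, an at least 2.4-fold lower number from compound 1 to compound 2 (0.38 log units; beyond the scatter), replaced a chain bearing an ether oxygen with a ring of carbon only, and it went toward a lower number.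

Compound 3 is `CC(C)C(C)Oc1cccc2ccc(N)nc12`. The change from compound 2 is 1,2-dimethylpropyl in place of 3-methylcyclopentyl on an oxygen on an aromatic ring. The ring is opened into a branched chain of similar size, without bringing back the ether oxygen that compound 1 carried. The step from compound 1 to compound 2 bears on this only loosely, since it shows that the ring is workable, but it gives no direct comparison of a ring against an open branched chain. A small step, within or near the scatter and most likely toward a slightly higher number, is expected as a 1.5-fold higher number from compound 2 to compound 3 (0.16 log units; within the scatter). Compound 3 is therefore estimated at 1200 nM, with a range from 400 nM to 3500 nM.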

Compound 3, half-maximal inhibitory concentration: 199 nM
Estimate against measurement, compound 3: 6.0-fold (0.78 log units) above; the whole stated range lies above it.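

Opening the ring gave more than a small adjustment, a 4.1-fold lower number from compound 2 to compound 3 (0.62 log units; beyond the scatter), so at this place, on an oxygen on an aromatic ring, a ring of carbon is not needed and the open, branched 1,2-dimethylpropyl does better in this assay. Both groups are carbon only and have no hydrogen-bond donors or acceptors, so this gain came with no change in those counts, although ring and size changed together. The branched chain also compares well with the ether chain, an at least 10-fold lower number from compound 1 to compound 3 (1.00 log units; beyond the scatter), but that step gives only a bound, as the value of compound 1 is a limit and not a number: the limit of > 2000 nM in this assay, at which 1 of the 3 values shown sits.

The compounds shown cannot separate the loss of the ring from the loss of one carbon, and they do not tell which of the branches in 1,2-dimethylpropyl matters. On these data alone, it also remains open how a smaller branched group such as isopropyl, a longer branched chain such as 1,3-dimethylbutyl, or a chain carrying an amine would fare at this oxygen.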